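Methoxy for Trifluoromethyl on the Chlorophenyl Core

This account rests on a few compounds, and the source may have more. Where it says the series, first, only, none or still open, it means among the compounds named here.

Three amides have been measured in a functional assay on NIH3T3 cells for agonist activity at Urotensin-2 receptor (Homo sapiens), with a stated time of 5 days; on this read-out lower numbers stand for smaller maximal responses and higher numbers for larger maximal responses. Compound 1 `COc1ccc(CCC(=O)NC(CCN(C)C)c2ccc3ccccc3c2)cc1` gives 113%, compound 2 `CN(C)CCC(NC(=O)CCc1ccc(C(F)(F)F)cc1)c1ccc2ccccc2c1` gives 75%, and compound 3 `CN(C)CCC(NC(=O)CCc1ccc(C(F)(F)F)cc1)c1ccc(Cl)cc1` gives 73%. The exchange of methoxy in place of trifluoromethyl on an aromatic carbon yields a number 38 percentage points higher from compound 2 to compound 1 (beyond the scatter). Changing the core, (4-chlorophenyl in place of naphthalen-2-yl on a saturated chain carbon bound to an amide-type nitrogen and a saturated chain carbon), yields a number 2 percentage points lower from compound 2 to compound 3 (within the scatter), so compound 2 and compound 3 stand within the scatter of each other.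

Compound 4 `COc1ccc(CCC(=O)NC(CCN(C)C)c2ccc(Cl)cc2)cc1` has not yet been measured in this assay. It differs from compound 3 by methoxy in place of trifluoromethyl on an aromatic carbon, which is the same change as that from compound 2 to compound 1, made on the core of compound 3 rather than on that of compound 2; the two cores differ as described above.

Since the same change on the other core produced a number 38 percentage points higher from compound 2 to compound 1 (beyond the scatter), and the cores themselves gave only a number 2 percentage points lower from compound 2 to compound 3 (within the scatter), a rise of similar size is expected for compound 4, that is a number 32 percentage points higher from compound 3 to compound 4 (beyond the scatter). Compound 4 is therefore estimated at 105% in this assay, with a likely range from 85% to 125%.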

Compound 4, largest response reached (reported as efficacy), in percent of the reference or control that the assay uses: 101%
For compound 4 the middle estimate is 4 percentage points above the measured one, and the stated range covers the measured number.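

In this assay the exchange of trifluoromethyl for methoxy on the core of compound 3 gives a number 28 percentage points higher from compound 3 to compound 4 (beyond the scatter), so the rise seen on the other core appears here as well. Set side by side, the two steps do not differ beyond the scatter: the same change on two cores in this assay, a number 38 percentage points higher (beyond the scatter) from compound 2 to compound 1 and a number 28 percentage points higher (beyond the scatter) from compound 3 to compound 4, 10 percentage points apart, within the scatter of two such steps. The change therefore carried over between these two cores in direction and, within the scatter, in size, but this is a single comparison: it does not show that the change would hold on any further core, nor why methoxy gives the larger maximal response.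

The compounds shown leave open how other groups at the same place on the aromatic ring, such as a hydroxyl, a fluorine or an ethoxy, would compare with methoxy and trifluoromethyl. They also leave open whether the exchange would keep its effect with a longer chain between the amide and the aromatic ring, or with another amine in place of the dimethylamine.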